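Extending a methoxy tail to benzyloxy in a receptor binding series

The compounds below may be only part of what the source reports. "The series", "measured", "known", "first", "only" and "open" are said of these compounds alone.

Measured compounds:
Compound 1, `O=C(O)CC1COc2cc(OCc3cccc(-c4ccc5sccc5c4)c3)ccc21`, > 10000 nM in an assay on CHO cells for displacement of a labelled ligand from Free fatty acid receptor 1 (Rattus norvegicus), read by scintillation counting, with a stated time of 90 min, in the presence of a further agent that is not named here; a higher number here means a weaker inhibitor, a lower number a stronger inhibitor
Compound 2, `COc1ccc(COc2ccc3c(c2)OCC3CC(=O)O)cc1-c1c(C)cccc1C`, 1600 nM

Of the compounds shown here, two have numbers so far. Compound 1, with its benzothiophene tail, returns only a limit in this assay; its value of > 10000 nM is not a measured number but the upper bound of the assay (the limit of > 10000 nM in this assay, at which 1 of the 2 values shown sits). Among the compounds with values here, compound 2 is therefore the only compound with a real value, and in this assay compound 2 gives 1600 nM.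

The next compound, compound 3, is `Cc1cccc(C)c1-c1cc(COc2ccc3c(c2)OCC3CC(=O)O)ccc1OCc1ccccc1`. It differs from compound 2 in one place: phenyl in place of hydrogen on a saturated chain carbon bound to an oxygen on an aromatic ring. Within the data shown here, no measured pair in this set shows the effect of such an extension, so the expectation rests on compound 2 alone. A change of this size is expected to move the value from compound 2 to compound 3 by about a 2.0-fold lower number from compound 2 to compound 3 (0.30 log units; within the scatter), toward stronger binding, but not far beyond the usual scatter. Compound 3 is accordingly estimated at 800 nM in this assay, with a range from 200 nM to 4000 nM.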

Compound 3, inhibition constant: 170 nM
The estimate for compound 3 lay 4.7-fold (0.67 log units) above the measured number; the measured number lies below the stated range.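

In this assay, the saturated chain carbon bound to an oxygen on an aromatic ring accepts a much larger group: phenyl in place of hydrogen, which turns methoxy into benzyloxy, gives a 9.4-fold lower number from compound 2 to compound 3 (0.97 log units; beyond the scatter). Within the data shown here, this is the first change in one place that can be sized here, and it shows that extending the tail at this position goes with stronger binding, not with a loss. No measurement shown here accounts for the size of this gain.

On these data alone, it remains open whether the gain belongs to the aromatic ring itself or simply to the added bulk and length, a question that a cyclohexyl group or a longer chain such as propoxy at this place would address. As far as these compounds go, how far a fluorine or an amine on the new phenyl ring would move the binding is also open.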